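This account rests on a few compounds, and the source may have more. Where it says the series, first, only, none or still open, it means among the compounds named here.

Of the compounds shown here, three have been tested in a toxicity assay on THP-1 cells (Homo sapiens) for inhibition; on this read-out higher numbers stand for lower toxicity in this test and lower numbers for higher toxicity in this test. Compound 1, `Cn1c(-c2ccccc2F)cnc1NC(=O)c1ccc(F)cc1`, shows a reading of > 100000 nM, which is a limit of the assay rather than a number. Compound 2, `COc1ccc(-c2noc(NC(=O)c3ccc(F)cc3)c2C)cc1`, gives > 100000 nM in this assay, again a limit. Compound 3, `COc1ccc(-c2cnc(NC(=O)c3ccccn3)n2C)cc1`, gives > 100000 nM in this assay, also a limit. On this read-out compound 3 therefore stands where every other measured compound stands: the limit of > 100000 nM in this assay, at which 3 of the 3 values shown sit. For the measured compounds named here, no two measured compounds differ in only one place, so no single step between measured compounds can be read off.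

Compound 4, `CCCC(=O)Nc1ncc(-c2ccc(OC)cc2)n1C`, has not yet been measured in this assay. It differs from compound 3 in one place: propyl in place of pyridin-2-yl on a carbonyl carbon. Because (the limit of > 100000 nM in this assay, at which 3 of the 3 values shown sit), no step beyond the usual scatter is expected in either direction for this change, and the reading for compound 4 is expected to stay at the limit as well. Compound 4 is therefore estimated at 100000 nM in this assay, with a range from 50000 nM to 200000 nM. The step this estimate implies, a number no higher from compound 3 to compound 4 (the limit leaves the size open), is expected to be none beyond the scatter.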

Compound 4, half-maximal cytotoxic concentration: > 100000 nM
Compound 4: a limit, no number; the forecaster's own chance of this, stated with the estimate: 85%; the middle value lies on the limit itself.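

Compound 4 reads > 100000 nM in this assay, which is a limit of the assay and not a number. For the compounds shown here, compound 3 also sits at a limit, so no step between compound 3 and compound 4 can be read. The compounds shown leave open whether any structural change here alters the toxicity reading at all: the limit of > 100000 nM in this assay, at which 4 of the 4 values shown sit.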